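A sulfonyl swap from compound 2 to compound 3

The source may report more compounds than this note shows. Statements on the series, on what has been measured and on what is new or still open speak of the compounds shown alone.

In a physicochemical assay for lipophilicity, measured as octanol-water partition, at pH 7.4 (a lower number here means a more polar compound, a higher number a more lipophilic compound), compound 2 `Cc1ccc2[nH]c(C(=O)N[C@H]3CN(S(=O)(=O)c4cn(C)nc4C)C[C@@H]3C(=O)NCCN(C)C)cc2c1` stands highest of the two measured compounds at 1.4, while compound 1 `Cc1ccc2[nH]c(C(=O)N[C@H]3CN(S(=O)(=O)c4ccnnc4)C[C@@H]3C(=O)NCCN(C)C)cc2c1` gives 0.7. Compound 3 `Cc1ccc2[nH]c(C(=O)N[C@H]3CN(S(=O)(=O)C4CCOCC4)C[C@@H]3C(=O)NCCN(C)C)cc2c1` carries oxan-4-yl in place of 1,3-dimethyl-1H-pyrazol-4-yl on a sulfonyl sulfur. Among the compounds with values here, one measured step bears on this change at the same place: a number 0.70 log units higher from compound 1 to compound 2 (beyond the scatter). Within the data shown here, no measured compound carries oxan-4-yl, so that step is only a rough guide. A small fall, not clearly beyond the scatter, is expected, a number 0.30 log units lower from compound 2 to compound 3 (within the scatter). Compound 3 is estimated at 1.1, with an expected range of 0.7 to 1.5.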

Compound 3, distribution coefficient: 1
The estimate for compound 3 lay 0.10 log units above the measured number; measured number inside the range.
By their numbers in this assay, from the lowest: compounds 1 and 3 (each within the scatter of the next); then compound 2.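

In this assay the change to oxan-4-yl, a six-membered non-aromatic ring on the sulfonyl sulfur, gives a number 0.40 log units lower from compound 2 to compound 3 (beyond the scatter) and thus shows that the 1,3-dimethyl-1H-pyrazol-4-yl compound is not matched by every ring at this place. Set against pyridazin-4-yl, the same ring gives a number 0.30 log units higher from compound 1 to compound 3 (within the scatter) and so an aromatic and a non-aromatic ring can read alike here. Nothing available explains either step. Open, from the compounds shown here alone, is where a piperidine ring, with nitrogen in place of the ring oxygen, or an open ethyl chain on the sulfonyl sulfur would stand.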